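This account rests on a few compounds, and the source may have more. Where it says the series, first, only, none or still open, it means among the compounds named here.

Compound 3 `C=C(C)CN(C1=NCCN1)c1c(Br)cccc1Br`, tested in a physicochemical assay for acid dissociation, gives 10.7. Compound 2 `C=CCN(C1=NCCN1)c1c(Br)cccc1Br` gives 10.7, so the two sit level, together the lowest of the three numbers, while compound 1 `Brc1ccc(N(CC2CC2)C2=NCCN2)c(Br)c1` gives 11.2, a number higher than that of compound 3 by a margin beyond the scatter. Compound 4 `Brc1cccc(Br)c1N(C1=NCCN1)C1CCCC1` has not been measured; it differs from compound 3 by cyclopentyl in place of 2-methylprop-2-en-1-yl on a nitrogen on an aromatic ring. Going by the values given here, the one measured step that alters the same chain on that nitrogen, no change at the digits printed from compound 2 to compound 3 (within the scatter), lies within the scatter. Among the compounds with values here, no single step links compound 1 to compound 3. Those two differ in more than one place. The expected step for compound 4 is therefore a number 0.10 log units higher from compound 3 to compound 4 (within the scatter), nothing beyond the scatter. Compound 4 is thus estimated at 10.8, between 10.4 and 11.3.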

Compound 4, acid dissociation constant: 11.2
For compound 4 the middle estimate is 0.40 log units below the measured one; the range from low to high includes it.
By their numbers in this assay, from the lowest: compounds 2 and 3 (each within the scatter of the next); then compounds 1 and 4 (each within the scatter of the next).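

In this assay, cyclopentyl on the nitrogen gives a number 0.50 log units higher from compound 3 to compound 4 (beyond the scatter), and the same replacement of allyl gives a number 0.50 log units higher from compound 2 to compound 4 (beyond the scatter). The number at this position therefore can move beyond the scatter, which adding a methyl to the chain did not show. Nothing available accounts for the rise. The change brings in a ring and removes a double bond together, so the two cannot be told apart. A saturated open chain such as isobutyl on that nitrogen would separate them.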